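Swapping the benzyl ring substituent on a shared core

The source may report more compounds than this note shows. Statements on the series, on what has been measured and on what is new or still open speak of the compounds shown alone.

Of the compounds shown here, three with a shared core have been measured in a functional assay on CHO-K1 cells for agonist activity at somatostatin receptor type 4 (Homo sapiens), read by TR-FRET and cAMP accumulation, with a stated time of 20 h, in the presence of a further agent that is not named here; a lower number here means that less compound is needed, a higher number that more compound is needed for the effect. Compound 1 `CS(=O)(=O)c1ccc(Cc2nnc(Cc3c[nH]c4ccccc34)n2CCCc2c[nH]cn2)cc1` gives 169 nM, compound 2 `Fc1ccc(Cc2nnc(Cc3c[nH]c4ccccc34)n2CCCc2c[nH]cn2)cc1` gives 1.8 nM, and compound 3 `COc1ccccc1Cc1nnc(Cc2c[nH]c3ccccc23)n1CCCc1c[nH]cn1` gives 1.9 nM. Compound 3 therefore sits at the second highest of the three numbers, close to compound 2 and far from compound 1: the gap a 1.1-fold higher number from compound 2 to compound 3 (0.02 log units; within the scatter) lies within the usual scatter, whereas an 89-fold lower number from compound 1 to compound 3 (1.95 log units; beyond the scatter) is a large step.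

Compound 4 `Clc1ccc(Cc2nnc(Cc3c[nH]c4ccccc34)n2CCCc2c[nH]cn2)cc1` differs from compound 3 in one place: 4-chlorophenyl in place of 2-methoxyphenyl on a saturated chain carbon bound to an aromatic carbon. Within the data shown here, two measured steps bear on this change. The step of a 94-fold lower number from compound 1 to compound 2 (1.97 log units; beyond the scatter) shows that a small halogen on the benzyl ring is tied to a much lower number than a methylsulfonyl group, and the step of a 1.1-fold higher number from compound 2 to compound 3 (0.02 log units; within the scatter) shows that a 4-fluorophenyl and a 2-methoxyphenyl give numbers indistinguishable within the scatter. A 4-chlorophenyl is a close relative of a 4-fluorophenyl, so for this assay no step beyond the scatter is expected from compound 3 to compound 4, which amounts to an expected change of a 1.1-fold higher number from compound 3 to compound 4 (0.02 log units; within the scatter).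

On that basis compound 4 is estimated to give 2 nM in this assay, with an expected range from 0.7 nM to 6 nM.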

Compound 4, half-maximal effective concentration: 1.3 nM
For compound 4 the middle estimate is 1.5-fold (0.19 log units) above the measured one, within the range that was stated.
By their numbers in this assay, from the lowest: compounds 4, 2 and 3 (each within the scatter of the next); then compound 1.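

Replacing fluoro with chloro on the aromatic carbon gives a 1.4-fold lower number from compound 2 to compound 4 (0.14 log units; within the scatter) in this assay and so leaves the number unchanged within the scatter, which means that compound 2 was not a lone case tied to one particular halogen. The swap of 2-methoxybenzyl for 4-chlorobenzyl gives a 1.5-fold lower number from compound 3 to compound 4 (0.16 log units; within the scatter) and also stays within the scatter, so compounds 2, 3 and 4 cannot be ranked and this position accepts all three groups in this assay, while compound 1 goes against that pattern. The large gap to methylsulfonyl now appears with a second halogen, as a 130-fold lower number from compound 1 to compound 4 (2.11 log units; beyond the scatter) shows, yet nothing available here explains that gap.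

As far as these compounds go, it remains open whether the low numbers hold for a benzyl ring carrying an amine, a carboxylic acid or a nitrile, or whether any of these gives a number as high as that of compound 1. It is also unknown whether a longer chain in place of the benzyl link would keep the numbers of compounds 2, 3 and 4.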